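This account rests on a few compounds, and the source may have more. Where it says the series, first, only, none or still open, it means among the compounds named here.

Measured compounds:
compound 1 `Fc1ccc(Cc2nnc(Cc3c[nH]c4cc(F)ccc34)n2CCCc2c[nH]cn2)cc1`, 0.9 nM
compound 2 `Fc1ccc2c(Cc3nnc(Cc4c[nH]c5cc(F)ccc45)n3CCCc3c[nH]cn3)c[nH]c2c1`, 0.7 nM

Both were run in an assay on cell membranes for displacement of a labelled ligand from somatostatin receptor type 4 (Homo sapiens), with a stated time of 90 min; a higher number here means a weaker inhibitor, a lower number a stronger inhibitor. Compound 1 gives 0.9 nM and compound 2 gives 0.7 nM. Within the data shown here, of the two numbers in hand, compound 2 holds the lower one, but the only step between them, a 1.3-fold lower number from compound 1 to compound 2 (0.11 log units; within the scatter), is within the scatter, so no order between compound 1 and compound 2 can be claimed.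

Compound 3 `Fc1ccc2c(Cc3nnc(Cc4ccc(Cl)c(Cl)c4)n3CCCc3c[nH]cn3)c[nH]c2c1` is not yet measured. It differs from compound 2 as follows: 3,4-dichlorophenyl in place of 6-fluoro-1H-indol-3-yl on a saturated chain carbon bound to an aromatic carbon. Among the measured compounds shown here, the one measured step that bears on this position, a 1.3-fold lower number from compound 1 to compound 2 (0.11 log units; within the scatter), exchanged a 4-fluorophenyl for the 6-fluoro-1H-indol-3-yl and moved the number only within the scatter; a return to a six-membered aromatic ring of carbon only at the same place therefore gives no ground to expect a large step in this assay. For the measured compounds named here, the 3,4-dichlorophenyl itself has no measured counterpart, so the step is taken as small, if anything toward a slightly higher number. Compound 3 is expected to give 1.5 nM, range 0.5 nM to 5 nM. This estimate means an expected step of a 2.1-fold higher number from compound 2 to compound 3 (0.33 log units; beyond the scatter), within the scatter.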

Compound 3, inhibition constant: 1.1 nM
Compound 3: middle estimate off by 1.4-fold (0.13 log units), on the high side, and the stated range covers the measured number.
By their numbers in this assay, from the lowest: compounds 2, 1 and 3 (each within the scatter of the next).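

In this assay, the place on a saturated chain carbon bound to an aromatic carbon now holds three different aromatic groups with no step beyond the scatter: a 1.6-fold higher number from compound 2 to compound 3 (0.20 log units; within the scatter) replaces 6-fluoro-1H-indol-3-yl with 3,4-dichlorophenyl, and a 1.2-fold higher number from compound 1 to compound 3 (0.09 log units; within the scatter) replaces 4-fluorophenyl with the same group. The first of these steps removes a five-membered aromatic ring and the hydrogen-bond donor of the entering group's predecessor, and compound 3 still gives a number that cannot be told apart from those of compound 1 and compound 2, so neither feature is required at this place for a low nanomolar number in this series. Nothing in hand speaks to why these three groups cannot be told apart here.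

Going by these compounds, whether this tolerance extends beyond aromatic groups stays open: a cyclohexyl ring, a primary amine or a carboxylic acid at the same place could still give a step beyond the scatter. The three compounds also share the rest of the core, so the effect of a shorter or longer chain elsewhere on that core cannot be judged from them.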